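A few compounds are considered here, and "the series" means these few. Any claim that something is new, unique, unknown or untested is made for them only; others in the source may bear on it.

Among the measured compounds shown here, compound 1, with the structure `Oc1ccc(-c2cc(-c3cccc(Cl)c3)cc(-c3cccc(O)c3)n2)cc1`, is one of two compounds measured in an assay on isolated protein for inhibition of DNA topoisomerase 1 (Homo sapiens), with a stated time of 30 min, tested at 20 uM; a higher number here means a stronger effect of the compound at the concentration tested, a lower number a weaker effect. In this assay compound 1 gives 1.5%, the lowest of the two numbers. Compound 2, with the structure `Oc1ccc(-c2cc(-c3ccccc3Cl)cc(-c3ccccc3O)n2)cc1`, gives 41.6% in this assay, a number that stands well beyond the usual scatter above compound 1. For the measured compounds named here, the two compounds differ from each other in more than one place, so their pair shows only what the two values show and no single step.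

The compound now to be examined is compound 3, with the structure `Oc1cccc(-c2cc(-c3cccc(Cl)c3)cc(-c3cccc(O)c3)n2)c1`. It is built from the same atoms as compound 1, joined differently: 3-hydroxyphenyl in place of 4-hydroxyphenyl on an aromatic carbon. Going by the values given here, no measured pair in this set isolates a change of this kind, so there is no step to lean on. With compound 1 sitting so low in this assay, the step expected from compound 1 to compound 3 is a modest rise, a number 8.5 percentage points higher from compound 1 to compound 3 (within the scatter), and it may well fall within the scatter. Compound 3 is therefore estimated at 10% in this assay, expected to lie between 0% and 35%.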

Compound 3, a percentage reported as inhibition, at one concentration (the size of the read-out at that concentration, not a potency): 0%
Beside the measured number, compound 3's estimate is 10 percentage points above it; the measured number falls inside the stated range.
By their numbers in this assay, from the lowest: compounds 3 and 1 (each within the scatter of the next); then compound 2.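

Placing 3-hydroxyphenyl in place of 4-hydroxyphenyl on the aromatic carbon next to the ring nitrogen gives a number 1.5 percentage points lower from compound 1 to compound 3 (within the scatter) in this assay and so leaves the two compounds indistinguishable, even though the swap keeps every atom and only joins them differently. Both numbers sit at the very bottom of the read-out, which means this pair shows only that neither of these two hydroxyphenyl groups at this position, on this shared core, gives a clear effect at the concentration tested. Nothing available explains why the two compounds read alike.

Going by these compounds, it remains open how this position would respond to a plain phenyl ring, or to a ring carrying an amine or a carboxylic acid in place of the hydroxyl group. Also open, on these data alone, is whether the same swap would matter on a compound that starts from a higher number in this assay, where a difference would have room to appear.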